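A Phenyl for a Methoxy on the Fused Core

The compounds below may be only part of what the source reports. "The series", "measured", "known", "first", "only" and "open" are said of these compounds alone.

In a functional assay on HCT-116 cells (Homo sapiens) for antiproliferative activity, read by MTT assay, with a stated time of 68 h (a higher number here means a weaker inhibitor, a lower number a stronger inhibitor), compound 1 `O=S(=O)(Nc1ccc(F)c(C#Cc2cnc3[nH]ncc3c2)c1F)c1ccccn1` gives only a limit of the assay, > 10000 nM. Compound 2 `O=S(=O)(Nc1ccc(F)c(C#Cc2cnc3[nH]ccc3c2)c1F)c1cccnc1` likewise gives only a limit, > 10000 nM. Among the measured compounds shown here, compound 3 `COc1n[nH]c2ncc(C#Cc3c(F)ccc(NS(=O)(=O)c4cccnc4)c3F)cc12` is the one member of the set with a numerical value in this assay, 1280 nM. It stands alone there, since the other two compounds sit at a limit rather than at a number (the limit of > 10000 nM in this assay, at which 2 of the 3 values shown sit). For the measured compounds named here, no step between two measured compounds that differ in a single place is available; compound 3 differs from compound 1 and from compound 2 in more than one place, and those differences are not broken down.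

Compound 4 `O=S(=O)(Nc1ccc(F)c(C#Cc2cnc3[nH]nc(-c4ccccc4)c3c2)c1F)c1cccnc1` differs from compound 3 in one place: phenyl in place of methoxy on an aromatic carbon. Going by the values given here, with no measured step to lean on, the direction is open; a move either way beyond the usual scatter is possible, and a return to the limit cannot be excluded. Compound 4 is expected to come in near 2000 nM, between 400 nM and 10000 nM. The step of a 1.6-fold higher number from compound 3 to compound 4 (0.19 log units; within the scatter) is estimated to stay within the scatter.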

Compound 4, half-maximal inhibitory concentration: > 10000 nM
Compound 4: a limit, no number; the forecaster's own chance of this, stated with the estimate: 25%; middle value at least 5.0-fold (0.69 log units) from the limit.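

In this assay, among the compounds shown here, the earlier compounds offered no comparison of a single change, and this position now has one: phenyl in place of methoxy gives an at least 7.8-fold higher number from compound 3 to compound 4 (0.89 log units; beyond the scatter). For the compounds shown here, the step lies beyond the scatter, so on this aromatic carbon phenyl does not keep the activity seen with methoxy, and compound 3 remains the only compound in the set with a numerical value. Compound 4 gives only a limit, and it joins the other compounds that sit there: the limit of > 10000 nM in this assay, at which 3 of the 4 values shown sit.

From the compounds shown here alone, how far compound 4 lies from compound 3 stays open, since a limit gives no number, and this single exchange does not show which feature of either group matters. Going by these compounds, whether an amine, a methyl or an ethoxy group on this carbon would match or improve on compound 3 also remains open.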